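The compounds below may be only part of what the source reports. "The series", "measured", "known", "first", "only" and "open" are said of these compounds alone.

Going by the values given here, in an assay on T-REx-293 cells for inhibition of potassium channel subfamily T member 1 (Mus musculus), read by patch clamp (on this read-out higher numbers stand for weaker inhibition and lower numbers for stronger inhibition), compound 2 `COCc1cc(-c2noc([C@H](C)NC(=O)c3cc(C(F)(F)F)nn3C)n2)ccn1` gives 17100 nM, the higher of the two numbers measured so far, though its only neighbour, compound 1 `Cc1cc(-c2noc([C@H](C)NC(=O)c3cc(C(F)(F)F)nn3C)n2)ccn1` with 14500 nM, is separated from it by a 1.2-fold higher number from compound 1 to compound 2 (0.07 log units; within the scatter), a step that stays inside the usual scatter. Compound 3 `C[C@H](NC(=O)c1cc(C(F)(F)F)nn1C)c1nc(-c2ccnc(C(F)F)c2)no1` differs from compound 2 by difluoromethyl in place of methoxymethyl on an aromatic carbon. Among the compounds with values here, the one measured step that touches this part of the molecule is the step from compound 1 to compound 2, which replaced hydrogen with methoxy on the saturated chain carbon and moved the number by a 1.2-fold higher number from compound 1 to compound 2 (0.07 log units; within the scatter). Within the data shown here, no measured step exchanges the oxygen-bearing methoxymethyl for a fluorine-bearing difluoromethyl, so the expectation for compound 3 rests on that single small step alone. Compound 3 is therefore expected to sit close to compound 2, with a step of about a 1.1-fold lower number from compound 2 to compound 3 (0.06 log units; within the scatter) in this assay, and its estimated value is 15000 nM, with a range from 6000 nM to 40000 nM.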

Compound 3, half-maximal inhibitory concentration: 1250 nM
The estimate for compound 3 lay 12-fold (1.08 log units) above the measured number; measured number outside the range, below it.
By their numbers in this assay, from the lowest: compound 3; then compounds 1 and 2 (each within the scatter of the next).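

In this assay, going by these compounds alone, the group on the aromatic carbon next to the ring nitrogen matters far more than the earlier compounds suggested: difluoromethyl in place of methoxymethyl gives a 14-fold lower number from compound 2 to compound 3 (1.14 log units; beyond the scatter) and difluoromethyl in place of methyl gives a 12-fold lower number from compound 1 to compound 3 (1.06 log units; beyond the scatter) at this position. Methyl and methoxymethyl lie within the scatter of each other, so the large steps appear only with difluoromethyl, and neither of the other two groups goes against this among the three compounds. Nothing available gives a reason for the size of these steps. The compounds shown leave open whether trifluoromethyl, monofluoromethyl or a nitrile on this carbon would keep the lower number. They also leave open whether the step would keep its size if the trifluoromethyl elsewhere in the shared core gave way to a methyl.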